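Adding Chloro to the Hydroxylated Cyclic Urea

A few compounds are considered here, and "the series" means these few. Any claim that something is new, unique, unknown or untested is made for them only; others in the source may bear on it.

In an assay on RBL-1 cells for inhibition of Polyunsaturated fatty acid 5-lipoxygenase (Rattus norvegicus) (on this read-out higher numbers stand for weaker inhibition and lower numbers for stronger inhibition), compound 3 `CC1CN(c2ccccc2)NC(=O)N1O` gives 6000 nM, the second highest of the three numbers at hand. Compound 1 `CC1CN(c2cccc(F)c2)NC(=O)N1` gives 6300 nM, within the scatter of compound 3, while compound 2 `CC1CN(c2cccc(Cl)c2)NC(=O)N1` gives 2700 nM, the lowest of the three. Compound 4 `CC1CN(c2cccc(Cl)c2)NC(=O)N1O` carries chloro in place of hydrogen on an aromatic carbon. Among the compounds with values here, the one measured step that bears on this change is a 2.3-fold lower number from compound 1 to compound 2 (0.37 log units; beyond the scatter); it exchanges chloro for fluoro rather than for hydrogen, so it is only a partial guide. A modest fall in number is therefore expected for compound 4, about a 2.0-fold lower number from compound 3 to compound 4 (0.30 log units; within the scatter). Compound 4 is estimated at 3000 nM, with a range from 1200 nM to 7500 nM.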

Compound 4, half-maximal inhibitory concentration: 3900 nM
Estimate against measurement, compound 4: 1.3-fold (0.11 log units) below, within the range that was stated.
By their numbers in this assay, from the lowest: compounds 2, 4, 3 and 1 (each within the scatter of the next, the first and the last beyond it).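

Chloro in place of hydrogen on the aromatic carbon gives a 1.5-fold lower number from compound 3 to compound 4 (0.19 log units; within the scatter), so on the hydroxylated compound this change does not move the number beyond the scatter. Hydroxy in place of hydrogen on the amide-type nitrogen gives a 1.4-fold higher number from compound 2 to compound 4 (0.16 log units; within the scatter), so with chloro present, that change also stays inside the scatter. No evidence at hand explains either step.

The compounds shown leave open whether a bromo, methyl or methoxy group on this aromatic carbon would shift the number further. On these data alone, it also remains open how a methoxy group or an amine would compare with hydroxy on the amide-type nitrogen.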